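Isobutyl for Trifluoromethylbenzyl on the Lactam Nitrogen

The source may hold more compounds than are shown below. What is called first, only, known or untested is meant among the compounds shown, and "the series" means these compounds.

Compound 1, `O=C(O)c1cc(-c2cccc(COc3ccc4c(=O)n(C5CCCC5)oc4c3)c2)ccc1Cl`, gives 310 nM in an assay on HEK293 cells for positive allosteric modulation of metabotropic glutamate receptor 2 (Rattus norvegicus), read by thallium flux; on this read-out higher numbers stand for an effect only at larger amounts of compound and lower numbers for an effect already at smaller amounts.
Compound 2, `O=C(O)c1cc(-c2cccc(COc3ccc4c(c3)CN(c3ccccc3)C4=O)c2)ccc1Cl`, gives 260 nM in this assay.
Compound 3, `O=C(O)c1cc(-c2cccc(COc3ccc4c(c3)CN(Cc3ccc(C(F)(F)F)cc3)C4=O)c2)ccc1Cl`, gives 350 nM in this assay.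

Among these three numbers compound 3 gives the highest, yet compound 1 and compound 2 both lie within the scatter of it, so the three compounds cannot be told apart in this assay. Compound 4, `CC(C)CN1Cc2cc(OCc3cccc(-c4ccc(Cl)c(C(=O)O)c4)c3)ccc2C1=O`, differs from compound 3 in one place: isopropyl in place of 4-(trifluoromethyl)phenyl on a saturated chain carbon bound to an amide-type nitrogen in a ring. Within the data shown here, the only measured step that bears on this position is a 1.3-fold higher number from compound 2 to compound 3 (0.13 log units; within the scatter), where one group on the amide-type nitrogen in a ring replaced another without a shift beyond the scatter. Compound 1, built on a different core, also sits within the scatter of compound 2 and compound 3. The numbers seen so far therefore show no sensitivity to the group at this place, and the step of a 1.1-fold higher number from compound 3 to compound 4 (0.06 log units; within the scatter) is expected to remain within the scatter. Compound 4 is thus estimated at 400 nM, with a range from 150 nM to 1100 nM.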

Compound 4, half-maximal effective concentration: 100 nM
Compound 4: middle estimate off by 4.0-fold (0.60 log units), on the high side; the measured number lies below the stated range.
By their numbers in this assay, from the lowest: compound 4; then compounds 2, 1 and 3 (each within the scatter of the next).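

In this assay, isobutyl in place of 4-(trifluoromethyl)benzyl on the amide-type nitrogen in a ring gives a 3.5-fold lower number from compound 3 to compound 4 (0.54 log units; beyond the scatter) and isobutyl in place of phenyl gives a 2.6-fold lower number from compound 2 to compound 4 (0.41 log units; beyond the scatter) on the same nitrogen. The position is therefore not indifferent to its group, which the earlier step, a 1.3-fold higher number from compound 2 to compound 3 (0.13 log units; within the scatter) with the core unchanged, could not show. Among these compounds, on the shared core, the one group here without a ring stands below both groups that carry one, though three compounds are too few to make this a rule.

Going by these compounds, whether the lower number belongs to isobutyl alone stays open, since a shorter or longer chain, or a chain ending in an amine or a hydroxyl group, could do the same or better. Nothing available here accounts for the change at this nitrogen.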